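This account rests on a few compounds, and the source may have more. Where it says the series, first, only, none or still open, it means among the compounds named here.

Compounds measured in a functional assay on P388 cells (Mus musculus) for inhibition; on this read-out higher numbers stand for weaker inhibition and lower numbers for stronger inhibition:
Compound 1, `CC1(CO)OCC(n2ccc(N)nc2=O)O1`, gives 10000 nM.
Compound 2, `C[C@]1(CO)OCC(n2ccc(N)nc2=O)O1`, reaches only a limit, > 100000 nM.

Compound 2 thus stands at a limit of this assay and not at a number. The step of an at least 10-fold higher number from compound 1 to compound 2 (1.00 log units; beyond the scatter) rests on the limit of > 100000 nM in this assay, at which 1 of the 2 values shown sits, and on (the fact that one of compounds 1 and 2 is drawn with a defined configuration and the other without, at the place where they differ). Compound 3, `CC1(CO)OC[C@@H](n2ccc(N)nc2=O)O1`, differs from compound 2 in that (the two compounds have the same atoms and bonds; at least one stereo element is drawn with a configuration in one of them and without one in the other: 2 of 2 stereo elements differ; a stereocentre at a saturated ring carbon is drawn S in compound 2 and without a configuration in compound 3; a stereocentre at a saturated ring carbon is drawn without a configuration in compound 2 and S in compound 3). Among the compounds with values here, only the step from compound 1 to compound 2 bears on this change, and it ran toward weaker inhibition when one ring centre was given a configuration; compound 3 gives the other ring centre a configuration instead and leaves the first one open again. A return toward the number of compound 1 is possible, yet a step in either direction beyond the scatter cannot be excluded. Compound 3 is expected to give about 20000 nM, within 3000 nM to 100000 nM. This estimate corresponds to an expected step of an at least 5.0-fold lower number from compound 2 to compound 3 (0.69 log units; beyond the scatter).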

Compound 3, half-maximal inhibitory concentration: > 100000 nM
Compound 3 ended at the assay's limit (the forecaster's own chance of this, stated with the estimate: 35%); middle value at least 5.0-fold (0.69 log units) away from the limit.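

In this assay compound 3 stands at a limit, > 100000 nM. The second saturated ring carbon, drawn S, therefore also goes with an at least 10-fold higher number from compound 1 to compound 3 (1.00 log units; beyond the scatter), so among these compounds a defined configuration at either centre comes with weaker inhibition than the open drawing of compound 1, and the link rests on this single comparison for this centre: the fact that one of compounds 1 and 3 is drawn with a defined configuration and the other without, at the place where they differ The step from compound 2 to compound 3 cannot be read, as both ends are limits.

Still open, going by these compounds, is how the opposite configuration at each centre reads, and whether a compound with both centres drawn reaches a number in this assay. Also open, on these data alone, is whether an amine or a carboxylic acid on the shared core would bring a compound with a defined configuration back from the limit.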